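Second and third methoxy groups in a three-compound series

This account rests on a few compounds, and the source may have more. Where it says the series, first, only, none or still open, it means among the compounds named here.

Measured so far, in a functional assay on the whole organism (strain Swiss albino) with Mus musculus as the target, in the forced swim test, with a stated time of 5 min, at a dose of 0.5 mg/kg by the intraperitoneal route; on this read-out higher numbers stand for more inhibition at the one dose given (going by the name of the read-out) and lower numbers for less inhibition:
Compound 1, `COc1ccc(-c2cc3cc(C4C(C#N)=C(N)OC5=C4C(=O)CC(C)(C)C5)cc(C(C)C)c3oc2=O)cc1`, gives 64.9%.
Compound 2, `COc1ccc(-c2cc3cc(C4C(C#N)=C(N)OC5=C4C(=O)CC(C)(C)C5)cc(C(C)C)c3oc2=O)cc1OC`, gives 86.6%.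
Compound 3, `CCC(C)c1cc(C2C(C#N)=C(N)OC3=C2C(=O)CC(C)(C)C3)cc2cc(-c3ccc(OC)c(OC)c3)c(=O)oc12`, gives 57.4%.

Compound 2 differs from compound 1 by methoxy in place of hydrogen on an aromatic carbon, and the step was a number 21.7 percentage points higher from compound 1 to compound 2 (beyond the scatter). Compound 3 differs from compound 2 elsewhere, and there the step was a number 29.2 percentage points lower from compound 2 to compound 3 (beyond the scatter). Compound 3 holds the lowest number of the three, though its gap to compound 1 lies within the scatter. The difference between the core of compound 3 and the core of compound 1 is not broken down here.

Compound 4, `CCC(C)c1cc(C2C(C#N)=C(N)OC3=C2C(=O)CC(C)(C)C3)cc2cc(-c3cc(OC)c(OC)c(OC)c3)c(=O)oc12`, is not yet measured. It differs from compound 3 by methoxy in place of hydrogen on an aromatic carbon. This is the same kind of change as that between compound 1 and compound 2, not the same change: the entering methoxy here is also meta to a methoxy group, which the earlier place lacked. Going by the values given here, only one precedent exists, the step of a number 21.7 percentage points higher from compound 1 to compound 2 (beyond the scatter). Resting on it, the expected step is a number 12.6 percentage points higher from compound 3 to compound 4 (beyond the scatter), taken smaller than the earlier one since the surroundings of the place differ. Compound 4 is thus expected to give about 70%, estimated between 52% and 88%.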

Compound 4, a percentage reported as inhibition, in the whole organism at one dose (the size of the read-out at that dose, not a potency): 28.2%
For compound 4 the middle estimate is 41.8 percentage points above the measured one; measured number outside the range, below it.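

Notes on the aromatic methoxy change: in this assay the change from 3,4-dimethoxyphenyl to 3,4,5-trimethoxyphenyl gives a number 29.2 percentage points lower from compound 3 to compound 4 (beyond the scatter) and so does not repeat the earlier gain. Methoxy in place of hydrogen on an aromatic carbon therefore does not carry over between these two cores as a fixed increment, and its direction is not preserved: the same change on two cores in this assay, a number 21.7 percentage points higher (beyond the scatter) from compound 1 to compound 2 and a number 29.2 percentage points lower (beyond the scatter) from compound 3 to compound 4, 50.9 percentage points apart, beyond the scatter of two such steps.

This does not show what drives the difference, since the two steps differ both in the core and in the surroundings of the place, where the entering methoxy of compound 4 is ortho to a methoxy group and meta to a methoxy group. Each direction also rests on a single pair of compounds.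

Still open, from the compounds shown here alone, is whether 3,4,5-trimethoxyphenyl on the core of compound 1 would follow the same course as on the core of compound 3. Also open, going by these compounds, is how a hydroxyl group, a fluorine atom or an amine would compare with methoxy at the same place on the ring.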